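The source may report more compounds than this note shows. Statements on the series, on what has been measured and on what is new or still open speak of the compounds shown alone.

Working notes on the series. Compound 1 `Cc1nn(C)c(Oc2ccc(F)cc2F)c1/C=N\CCCCCCOc1cc2oc(=O)cc(C)c2cc1Cl` and compound 2 `Cc1nn(C)c(Oc2cccc(Cl)c2)c1/C=N\CCCCCCOc1cc2oc(=O)cc(C)c2cc1Cl` share one core and differ only in the aryl group on the ether oxygen. In a functional assay on U-87MG ATCC cells for antiproliferative activity against U-87 MG (Homo sapiens), read by MTT assay, with a stated time of 72 h (on this read-out higher numbers stand for weaker inhibition and lower numbers for stronger inhibition), compound 1 reports only a limit, > 25000 nM, as set out in the limit of > 25000 nM in this assay, at which 1 of the 2 values shown sits. In this assay, among the measured compounds shown here, compound 2 gives 8460 nM, the single full number in the set. For the measured compounds named here, the step of an at least 2.9-fold lower number from compound 1 to compound 2 (0.47 log units; beyond the scatter) is the one measured change, and it runs from a limit, so its true size is open. Compound 3 `Cc1nn(C)c(Oc2ccc(Cl)cc2)c1/C=N\CCCCCCOc1cc2oc(=O)cc(C)c2cc1Cl` is not yet measured; it carries 4-chlorophenyl in place of 3-chlorophenyl on an oxygen on an aromatic ring. Going by the values given here, the only measured step bears on it indirectly: it also moves the halogen pattern on the phenoxy group, but between two chlorine placements rather than a fluorine-to-chlorine exchange. No step within the scatter is shown to anchor the expectation, so a step of about a 1.1-fold higher number from compound 2 to compound 3 (0.03 log units; within the scatter), within the scatter, is expected. Compound 3 is therefore estimated at 9000 nM in this assay, with a range from 3000 nM to 25000 nM.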

Compound 3, half-maximal inhibitory concentration: 3850 nM
Beside the measured number, compound 3's estimate is 2.3-fold (0.37 log units) above it; the measured number falls inside the stated range.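

In this assay, moving the chlorine alone, with the same atoms joined differently, gives a 2.2-fold lower number from compound 2 to compound 3 (0.34 log units; beyond the scatter). The aryl group on the ether oxygen therefore responds to the placement of a single chlorine, and not only to the wider change away from 2,4-difluorophenyl. That wider change reads an at least 6.4-fold lower number from compound 1 to compound 3 (0.81 log units; beyond the scatter), and its true size stays open since it runs from a limit: the limit of > 25000 nM in this assay, at which 1 of the 3 values shown sits.

The compounds shown leave open whether a methoxyphenyl or a trifluoromethylphenyl group in place of 4-chlorophenyl on the same oxygen would keep or extend this step. They also leave open how a shorter or longer chain would read with 4-chlorophenyl in place.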